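Swapping a Bromo for a Hydroxy Group

The source may report more compounds than this note shows. Statements on the series, on what has been measured and on what is new or still open speak of the compounds shown alone.

In a functional assay on PC-3 cells (Homo sapiens) (a lower number here means a stronger inhibitor of growth, a higher number a weaker inhibitor of growth), compound 1 `O=S(=O)(/C=C/c1ccc(O)cc1)Cc1ccc(Nc2ncnc3ccccc23)cc1` gives 14000 nM while compound 2 `O=S(=O)(/C=C/c1ccc(Br)cc1)Cc1ccc(Nc2ncnc3ccc(Br)cc23)cc1` gives 34000 nM as the higher number of the two, a gap beyond the usual scatter. Compound 3 `O=S(=O)(/C=C/c1ccc(O)cc1)Cc1ccc(Nc2ncnc3ccc(Br)cc23)cc1` differs from compound 2 by hydroxy in place of bromo on an aromatic carbon and so carries the 4-hydroxyphenyl group also found in compound 1. Compound 1 stands at 14000 nM with that group, so a number lower than that of compound 2 is expected. The expected change is a small step of a 1.7-fold lower number from compound 2 to compound 3 (0.23 log units; within the scatter) toward stronger inhibition. For compound 3 the estimated value is 20000 nM with an expected range from 9000 nM to 42000 nM across repeated measurements.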

Compound 3, concentration for 50% growth inhibition: 42000 nM
Compound 3: middle estimate off by 2.1-fold (0.32 log units), on the low side; the measured number falls inside the stated range.
By their numbers in this assay, from the lowest: compound 1; then compounds 2 and 3 (each within the scatter of the next).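

In this assay, changing 4-bromophenyl to 4-hydroxyphenyl gives a 1.2-fold higher number from compound 2 to compound 3 (0.09 log units; within the scatter), so this swap has no readable effect on growth inhibition when the core carries its bromo. The other new comparison, bromo in place of hydrogen on an aromatic carbon of the core, gives a 3.0-fold higher number from compound 1 to compound 3 (0.48 log units; beyond the scatter), a modest loss of growth inhibition. Nothing available explains either result.

As far as these compounds go, it remains open whether an amine or a carboxylic acid in place of the hydroxy would shift the number. From the compounds shown here alone, it is also open whether the bromo-to-hydroxy swap would stay this small on a core without bromo.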